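Chloro in Place of Methyl on the Aromatic Ring

This account rests on a few compounds, and the source may have more. Where it says the series, first, only, none or still open, it means among the compounds named here.

For the measured compounds named here, compound 2 `Cc1ccc(OC[C@@H]2C[C@H]3C[C@H]3N2C)cn1` gives 20 nM in an assay on CHO-K1 cells for displacement of a labelled ligand from Neuronal acetylcholine receptor; alpha4/beta2 (Homo sapiens), read by scintillation counting (a higher number here means a weaker inhibitor, a lower number a stronger inhibitor), the higher of the two numbers measured so far. Going by the values given here, its nearest neighbour is compound 1 `CN1[C@H](COc2cccnc2)C[C@H]2C[C@H]21`, which gives 5.5 nM in this assay; the single measured step, a 3.6-fold higher number from compound 1 to compound 2 (0.56 log units; beyond the scatter), separates them. Compound 3 `CN1[C@H](COc2ccc(Cl)nc2)C[C@H]2C[C@H]21` has not yet been measured. The change from compound 2 to compound 3 is chloro in place of methyl on an aromatic carbon. Among the compounds with values here, only one step bears on this: adding a methyl at this place raised the number, a 3.6-fold higher number from compound 1 to compound 2 (0.56 log units; beyond the scatter), so a single heavy atom there is tolerated, though it cost some affinity. Chloro is a group of the same size, so a number close to compound 2, or somewhat lower, is expected rather than a large move in either direction. The expected step is a 2.0-fold lower number from compound 2 to compound 3 (0.30 log units; within the scatter). Compound 3 is expected to give 10 nM in this assay, within a range of 3 nM to 35 nM.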

Compound 3, inhibition constant: 3.4 nM
Compound 3: middle estimate off by 2.9-fold (0.47 log units), on the high side; low and high end bracket the measured number.
By their numbers in this assay, from the lowest: compounds 3 and 1 (each within the scatter of the next); then compound 2.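

At this place, on the aromatic carbon next to the ring nitrogen, two groups of one heavy atom each do not behave alike in this assay: there is a 5.9-fold lower number from compound 2 to compound 3 (0.77 log units; beyond the scatter), so the count of heavy atoms alone does not set the number. Chloro also differs from methyl when each is set against hydrogen: a 1.6-fold lower number from compound 1 to compound 3 (0.21 log units; within the scatter) leaves compounds 1 and 3 indistinguishable, whereas methyl alone moved the number beyond the scatter. Nothing available explains why methyl and chloro part in this way.

What the compounds shown leave open is how other groups would fare at this carbon, for example fluoro, methoxy, an amine or a nitrile. They also leave open whether chloro would give a similar result on another carbon of the same ring.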